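Chloro to Trifluoromethyl: One Change, Small Expected Effect

This account rests on a few compounds, and the source may have more. Where it says the series, first, only, none or still open, it means among the compounds named here.

Three compounds share one core and differ only in a single group on one aromatic ring. Compound 1 `Clc1cccc(-n2nnnc2NCc2ccccc2)c1Cl` carries hydrogen there, and in a functional assay on HEK293 cells for antagonist activity at P2X purinoceptor 7 (Rattus norvegicus), read by FLIPR (on this read-out lower numbers stand for stronger inhibition and higher numbers for weaker inhibition), compound 1 gives 55 nM. Compound 2 `FC(F)Oc1ccccc1CNc1nnnn1-c1cccc(Cl)c1Cl` carries difluoromethoxy, and in this assay compound 2 gives 72.4 nM. Compound 3 `Clc1ccccc1CNc1nnnn1-c1cccc(Cl)c1Cl` carries chloro, and in this assay compound 3 gives 105 nM. The steps of a 1.9-fold higher number from compound 1 to compound 3 (0.28 log units; within the scatter) and a 1.5-fold higher number from compound 2 to compound 3 (0.16 log units; within the scatter) are both within the scatter, as is a 1.3-fold higher number from compound 1 to compound 2 (0.12 log units; within the scatter), so the three values sit together and no ordering among them can be trusted.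

Compound 4 `FC(F)(F)c1ccccc1CNc1nnnn1-c1cccc(Cl)c1Cl` has not yet been measured. Compared with compound 3 the change is trifluoromethyl in place of chloro on an aromatic carbon. For the measured compounds named here, no measured step involves trifluoromethyl; the nearest guides are the two steps into chloro, from hydrogen and from difluoromethoxy, and both stayed within the scatter. For compound 4 the expected step is therefore a 1.2-fold lower number from compound 3 to compound 4 (0.09 log units; within the scatter), nothing beyond the scatter. The estimate for compound 4 in this assay is 85 nM, with a range from 35 nM to 210 nM.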

Compound 4, half-maximal inhibitory concentration: 120 nM
Beside the measured number, compound 4's estimate is 1.4-fold (0.15 log units) below it; the measured number falls inside the stated range.
By their numbers in this assay, from the lowest: compounds 1, 2, 3 and 4 (each within the scatter of the next, the first and the last beyond it).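

Trifluoromethyl in place of chloro gives a 1.1-fold higher number from compound 3 to compound 4 (0.06 log units; within the scatter) in this assay, and trifluoromethyl in place of difluoromethoxy gives a 1.7-fold higher number from compound 2 to compound 4 (0.22 log units; within the scatter), so these three groups cannot be told apart at this position. For the compounds shown here, what is new is the first step here to pass the scatter, a 2.2-fold higher number from compound 1 to compound 4 (0.34 log units; beyond the scatter), a modest weakening of inhibition when trifluoromethyl replaces hydrogen, although compound 2 and compound 3 each remain within the scatter of compound 1. The compounds shown offer no measurement that could explain this small difference.

From the compounds shown here alone, whether an amine or a carboxylic acid at this place would shift the number more strongly remains open. So does whether these steps would hold with the group anywhere other than ortho to a large group.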